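Replacing the Sulfanyl Link at the Chain Carbon

This account rests on a few compounds, and the source may have more. Where it says the series, first, only, none or still open, it means among the compounds named here.

Three measured compounds share one core and differ only in the group on a saturated chain carbon bound to a carbonyl carbon. Compound 1 `CC(C)C[C@H](N)c1cc(C(F)(F)F)ccc1N1CCN(C(=O)COc2ccc(O)cc2)CC1` carries 4-hydroxyphenoxy there, and in an assay on HEK293 cells for displacement of a labelled ligand from Melanocortin receptor 4 (Homo sapiens) (a higher number here means a weaker inhibitor, a lower number a stronger inhibitor), compound 1 gives 4600 nM. Compound 2 `CC(C)C[C@H](N)c1cc(C(F)(F)F)ccc1N1CCN(C(=O)CNc2ccccc2)CC1` carries anilino, and in this assay compound 2 gives 3600 nM, a change of a 1.3-fold lower number from compound 1 to compound 2 (0.11 log units; within the scatter). Compound 3 `CC(C)C[C@H](N)c1cc(C(F)(F)F)ccc1N1CCN(C(=O)CSc2ccc(Cl)cc2Cl)CC1` carries (2,4-dichlorophenyl)sulfanyl, and in this assay compound 3 gives 1500 nM, the lowest of the three numbers, reached by a 3.1-fold lower number from compound 1 to compound 3 (0.49 log units; beyond the scatter) and by a 2.4-fold lower number from compound 2 to compound 3 (0.38 log units; beyond the scatter).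

Compound 4 `CC(C)C[C@H](N)c1cc(C(F)(F)F)ccc1N1CCN(C(=O)CC(C)C(=O)c2ccc(Cl)cc2)CC1` differs from compound 3 at the same place: 1-((4-chlorophenyl)carbonyl)ethyl in place of (2,4-dichlorophenyl)sulfanyl on a saturated chain carbon bound to a carbonyl carbon. Among the compounds with values here, no measured step exchanges for a group of this kind, so only the two steps leading into compound 3 bear on it. Both were modest, showing that swapping the group at this position shifts the number only moderately across the three groups tried. Since the group that gave the lowest number is removed, the step from compound 3 to compound 4 is expected to be a modest rise in the number, with a wide margin for either direction. Compound 4 is expected to give about 2800 nM, within 900 nM to 9000 nM, which would mean a 1.9-fold higher number from compound 3 to compound 4 (0.27 log units; within the scatter).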

Compound 4, inhibition constant: 1100 nM
Compound 4: middle estimate off by 2.5-fold (0.41 log units), on the high side; the measured number falls inside the stated range.
By their numbers in this assay, from the lowest: compounds 4 and 3 (each within the scatter of the next); then compounds 2 and 1 (each within the scatter of the next).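

The sulfur link of (2,4-dichlorophenyl)sulfanyl is not required for the lowest numbers seen at this position: in this assay, the sulfur-free 1-((4-chlorophenyl)carbonyl)ethyl gives a 1.4-fold lower number from compound 3 to compound 4 (0.13 log units; within the scatter) and so cannot be told apart from it. The new group also stands clear of the two earlier groups that carry no chlorine, with a 3.3-fold lower number from compound 2 to compound 4 (0.51 log units; beyond the scatter) and a 4.2-fold lower number from compound 1 to compound 4 (0.62 log units; beyond the scatter), so among these four compounds, the two with a chlorinated phenyl ring give the lower numbers and no compound goes against this. No measurement offered here explains why two such different groups give matching results.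

Within the data shown here, the single step from compound 3 to compound 4 changes the link, the chain and the chlorine count together, so it cannot show which of these changes, if any, matters on its own. Also open, as far as these compounds go, is how the number would respond to a carboxylic acid or an amine at the end of this chain, or to a longer chain carrying the same 4-chlorophenyl ring.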